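The source may report more compounds than this note shows. Statements on the series, on what has been measured and on what is new or still open speak of the compounds shown alone.

Measured compounds:
compound 1, `Cc1c(CO)cc2n1[C@@H](c1ccccc1)SC2` — 62900 nM
compound 2, `Cc1cc(CO)c2n1[C@@H](c1ccccc1)SC2` — 62100 nM

Of the compounds shown here, two sharing one core have been measured in a functional assay on A-375 cells (Homo sapiens) for cytotoxicity, read by MTT assay, with a stated time of 72 h; a higher number here means a weaker inhibitor, a lower number a stronger inhibitor. Compound 1, `Cc1c(CO)cc2n1[C@@H](c1ccccc1)SC2`, gives 62900 nM in this assay, and compound 2, `Cc1cc(CO)c2n1[C@@H](c1ccccc1)SC2`, gives 62100 nM. The two values lie so close that the data treat them as one and the same result; compound 2 therefore stands at the same place as compound 1, and neither can be set apart from the other. Both sit at a weak level of cytotoxicity.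

Compound 3, `Cc1c(CO)c(CO)c2n1[C@@H](c1ccccc1)SC2`, has not yet been measured in this assay. It differs from compound 2 by hydroxymethyl in place of hydrogen on an aromatic carbon. Going by the values given here, no measured pair shows what such a change does on this core, so the expectation rests on the closeness of the two measured values alone: the core carrying one hydroxymethyl group in either of two positions gives the same weak result, and a second hydroxymethyl is expected to leave this largely unchanged, with a step from compound 2 to compound 3 of a 1.0-fold lower number from compound 2 to compound 3 (0.01 log units; within the scatter), which is no more than the usual scatter. Compound 3 is accordingly estimated at 60000 nM in this assay, within a range from 25000 nM to 150000 nM.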

Compound 3, half-maximal inhibitory concentration: 27200 nM
Compound 3: the middle estimate sits 2.2-fold (0.34 log units) above what was measured, within the range that was stated.
By their numbers in this assay, from the lowest: compound 3; then compounds 2 and 1 (each within the scatter of the next).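

In this assay, going by these compounds alone, the earlier compounds showed only that a single hydroxymethyl group gave results within the scatter of each other at two places on the shared core, and no step could be read from them. Hydroxymethyl in place of hydrogen on the aromatic carbon next to the ring atom that bears a methyl group now gives a 2.3-fold lower number from compound 2 to compound 3 (0.36 log units; beyond the scatter), and the same exchange at the other place gives a 2.3-fold lower number from compound 1 to compound 3 (0.36 log units; beyond the scatter). Carrying both hydroxymethyl groups therefore moves the result modestly toward a stronger inhibitor, beyond the scatter, whichever singly substituted compound serves as the starting point, a shift that neither place had shown alone. Nothing in the data accounts for this step.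

From the compounds shown here alone, it remains open whether this shift is specific to hydroxymethyl or would also appear with another group on the same aromatic carbon, such as an amine, a carboxylic acid or a longer chain ending in hydroxyl. It is also open whether removing either hydroxymethyl group altogether would change the result in this assay, as the compounds shown all carry at least one.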